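The compounds below may be only part of what the source reports. "The series", "measured", "known", "first", "only" and "open" are said of these compounds alone.

Of the compounds shown here, three sharing one core have been measured in a functional assay on A549 cells (Homo sapiens) for antiproliferative activity, read by MTT assay, with a stated time of 72 h; on this read-out higher numbers stand for weaker inhibition and lower numbers for stronger inhibition. Compound 1 `CN(C(=O)C(C)(C)C)c1ccc2[nH]c(-c3n[nH]c4ccccc34)cc2n1` carries a tert-butyl group on the carbonyl carbon and gives 24400 nM. Compound 2 `CN(C(=O)c1ccc(Br)cc1)c1ccc2[nH]c(-c3n[nH]c4ccccc34)cc2n1` has a 4-bromophenyl group in that place and gives 4250 nM. Compound 3 `COc1ccc(C(=O)N(C)c2ccc3[nH]c(-c4n[nH]c5ccccc45)cc3n2)cc1` has a 4-methoxyphenyl group there and gives 14600 nM. Compound 3 stands second highest of the three numbers: its nearest neighbour is compound 1, since a 1.7-fold lower number from compound 1 to compound 3 (0.22 log units; within the scatter) lies within the scatter, while a 3.4-fold higher number from compound 2 to compound 3 (0.54 log units; beyond the scatter) sets it beyond the scatter from compound 2. The remaining step, a 5.7-fold lower number from compound 1 to compound 2 (0.76 log units; beyond the scatter), is the largest of the three.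

Compound 4 `COc1cccc(C(=O)N(C)c2ccc3[nH]c(-c4n[nH]c5ccccc45)cc3n2)c1` is not yet measured. It differs from compound 3 by 3-methoxyphenyl in place of 4-methoxyphenyl on a carbonyl carbon. For the measured compounds named here, no measured step moves a methoxy group from one place on the phenyl ring to another; the steps that bear on the question only show that exchanging the whole group on the carbonyl carbon shifts the number modestly at most, as seen in a 3.4-fold higher number from compound 2 to compound 3 (0.54 log units; beyond the scatter) and a 1.7-fold lower number from compound 1 to compound 3 (0.22 log units; within the scatter). The number for compound 4 is therefore expected to stay close to that of compound 3, with a 1.2-fold lower number from compound 3 to compound 4 (0.09 log units; within the scatter) expected to fall within the scatter. The estimate for compound 4 in this assay is 12000 nM, with a range from 4500 nM to 32000 nM.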

Compound 4, half-maximal inhibitory concentration: 14900 nM
For compound 4 the middle estimate is 1.2-fold (0.09 log units) below the measured one; the measured number falls inside the stated range.
By their numbers in this assay, from the lowest: compound 2; then compounds 3, 4 and 1 (each within the scatter of the next).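

In this assay, for the compounds shown here, this is the first direct test of where the methoxy group sits on the phenyl ring attached to the carbonyl carbon: a 1.0-fold higher number from compound 3 to compound 4 (0.01 log units; within the scatter) shows that going from 4-methoxyphenyl to 3-methoxyphenyl leaves the number within the scatter. Compound 4 also takes the same place among the other compounds as compound 3 does: a 3.5-fold higher number from compound 2 to compound 4 (0.54 log units; beyond the scatter) keeps it apart from the 4-bromophenyl compound, while a 1.6-fold lower number from compound 1 to compound 4 (0.21 log units; within the scatter) leaves it within the scatter of the tert-butyl compound, so that among these four only compound 2 stands apart. Nothing measured here accounts for the match between the two methoxy compounds or for the separate standing of compound 2.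

The compounds shown leave open whether the bromo group would tolerate the same move on the ring as the methoxy group did, and so whether the insensitivity seen here extends beyond methoxy. They also leave open what an amine or a carboxylic acid on the phenyl ring, or a longer chain in its place on the carbonyl carbon, would do to the number.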